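The source may report more compounds than this note shows. Statements on the series, on what has been measured and on what is new or still open speak of the compounds shown alone.

Measured so far:

Compound 1 `CO[C@@H]1CC=C2NN(c3cc4ccccc4[nH]3)C(=O)C[C@]2(C)O1` — 18300 nM
Compound 2 `CO[C@@H]1CC=C2NN(c3cc4ccccc4[nH]3)C(=O)C[C@]2(c2ccccc2)O1` — 8200 nM
Compound 3 `COc1cc(OC)cc(N2NC3=CC[C@@H](OC)O[C@@]3(c3ccccc3)CC2=O)c1` — 18100 nM

In a functional assay on HCT-116 cells (Homo sapiens) for inhibition, read by sulforhodamine B assay, with a stated time of 48 h (on this read-out lower numbers stand for stronger inhibition and higher numbers for weaker inhibition), compound 2 gives 8200 nM. The change methyl in place of phenyl on a saturated ring carbon gave a 2.2-fold higher number from compound 2 to compound 1 (0.35 log units; beyond the scatter). Compound 3 shares its core with compound 2 only in part; the difference between the two cores is not broken down here. Compound 4 `COc1cc(OC)cc(N2NC3=CC[C@@H](OC)O[C@@]3(C)CC2=O)c1` is made from compound 3 by methyl in place of phenyl on a saturated ring carbon. This is the same kind of change as from compound 2 to compound 1, but not the same: there the place was next to the ring oxygen and next to the ring atom that bears a fused ring, while here it is in a ring with 2 nitrogen, three ring bonds from the ring atom that bears a large group. Since it rests on one earlier step, compound 4 is expected to show a step of a 2.2-fold higher number from compound 3 to compound 4 (0.34 log units; beyond the scatter), like that from compound 2 to compound 1. The estimate for compound 4 is 40000 nM, expected between 18000 nM and 90000 nM.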

Compound 4, half-maximal inhibitory concentration: 24300 nM
The estimate for compound 4 lay 1.6-fold (0.22 log units) above the measured number; low and high end bracket the measured number.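

In this assay, methyl in place of phenyl on a saturated ring carbon gives a 1.3-fold higher number from compound 3 to compound 4 (0.13 log units; within the scatter), so on this core the effect of the swap cannot be told apart from the spread of repeated measurements. Set beside the same swap on the other core, the two steps do not differ by more than such steps normally would: the same change on two cores in this assay, a 2.2-fold higher number (0.35 log units; beyond the scatter) from compound 2 to compound 1 and a 1.3-fold higher number (0.13 log units; within the scatter) from compound 3 to compound 4, 1.7-fold (0.22 log units) apart, within the scatter of two such steps

This fits a change that carries over between the two cores, but two pairs are few, and they do not show that the step is truly equal on both or that it would hold on a further core.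

The compounds shown carry only methyl or phenyl on this carbon. Going by these compounds, how a longer chain, an amine or a carboxylic acid there would read remains open.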